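A large new group on a shared core

The compounds below may be only part of what the source reports. "The series", "measured", "known", "first", "only" and "open" are said of these compounds alone.

Compound 1 `CC(=O)N1CCN([C@H]2CC[C@H](Nc3ncnn4ccc([C@H]5CC[C@H](C(N)=O)CC5)c34)CC2)CC1`: < 0.7 10^-6 cm/s (a limit)
Compound 2 `Cc1ccn2ncnc(N[C@H]3CC[C@H](N(C)C)CC3)c12`: 36 10^-6 cm/s
Compound 3 `CC(C)c1ccn2ncnc(N[C@H]3CC[C@H](N(C)C)CC3)c12`: 26 10^-6 cm/s

These values come from an ADME assay on Caco-2 cells (Homo sapiens) for permeability, in the apical to basolateral direction; a higher number here means that the compound crosses the layer faster, a lower number that the compound crosses the layer more slowly. Compound 3 gives 26 10^-6 cm/s, which lies within the scatter of compound 2 at 36 10^-6 cm/s. Compound 4 `CN(C)[C@H]1CC[C@H](Nc2ncnn3ccc([C@H]4CC[C@H](C(N)=O)CC4)c23)CC1` carries 4-carbamoylcyclohexyl in place of isopropyl on an aromatic carbon. Among the measured compounds shown here, one measured step touches this place: a 1.4-fold lower number from compound 2 to compound 3 (0.14 log units; within the scatter). That step swapped methyl for isopropyl, a far smaller exchange, so it says little here. For the measured compounds named here, compound 1 is the only measured compound that already has 4-carbamoylcyclohexyl, although it differs elsewhere too. Compound 1 gives < 0.7 10^-6 cm/s, which is a limit of the assay. With that limit as the guide, a clear fall is expected, and the estimated change is a 13-fold lower number from compound 3 to compound 4 (1.11 log units; beyond the scatter). The result could also end up as a limit. For compound 4 the expected value is 2 10^-6 cm/s, with an estimated range of 0.6 10^-6 cm/s to 8 10^-6 cm/s.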

Compound 4, apparent permeability: < 0.8 10^-6 cm/s
Compound 4: only a limit was reported (the forecaster's own chance of this, stated with the estimate: 30%); middle value at least 2.5-fold (0.39 log units) away from the limit.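

In this assay, putting 4-carbamoylcyclohexyl on this aromatic carbon gives an at least 32-fold lower number from compound 3 to compound 4 (1.51 log units; beyond the scatter) and an at least 45-fold lower number from compound 2 to compound 4 (1.65 log units; beyond the scatter), whereas the exchange of methyl for isopropyl at the same place gave only a 1.4-fold lower number from compound 2 to compound 3 (0.14 log units; within the scatter). Compound 1 also differs elsewhere, but compound 4 differs from compound 2 and compound 3 in this one place, so the fall can now be tied to this change of group. Compound 4 reaches a limit of the assay, so the steps give only the least size of the fall: the limit of < 0.8 10^-6 cm/s in this assay, at which 1 of the 4 values shown sits.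

The step between compound 1 and compound 4 cannot be read. The compounds shown also do not separate the ring from the carbamoyl group, and a plain cyclohexyl at this position would be needed to tell whether the ring alone brings the fall.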